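Purine series: chloromethylbenzyl analogues, growth inhibition

The source may report more compounds than this note shows. Statements on the series, on what has been measured and on what is new or still open speak of the compounds shown alone.

Measured compounds:
compound 1 `ClCc1ccccc1Cn1cnc2c(Cl)nc(Cl)nc21` — 1510 nM
compound 2 `ClCc1ccccc1Cn1cnc2c(Cl)ncnc21` — 2040 nM
compound 3 `ClCc1ccc(Cn2cnc3nc(Cl)nc(Cl)c32)cc1` — 2340 nM

In a functional assay on NCI-H23 cells (Homo sapiens) for cytotoxicity, read by sulforhodamine B assay, with a stated time of 48 h (a lower number here means a stronger inhibitor of growth, a higher number a weaker inhibitor of growth), compound 2 gives 2040 nM. Among the three numbers it is the second highest; compound 3 gives 2340 nM, and the two lie within the scatter of each other. Compound 1 gives 1510 nM, again within the scatter of compound 2. Within the data shown here, the only one-place step among the measured compounds is a 1.4-fold higher number from compound 1 to compound 2 (0.13 log units; within the scatter), which is within the scatter, so the shared core tolerates either chloro or hydrogen at that aromatic carbon without a detectable shift in this assay.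

Compound 4 `Nc1nc(Cl)c2ncn(Cc3ccccc3CCl)c2n1` has not been measured. It differs from compound 2 in one place: amino in place of hydrogen on an aromatic carbon. Among the measured compounds shown here, this change sits at the same aromatic carbon that the step from compound 1 to compound 2 concerned, but no measured pair shows an amino group entering anywhere on the core, so no step directly bears on it. For the measured compounds named here, the one related step being within the scatter, no change beyond the scatter is expected from compound 2 to compound 4, and the estimated step is a 1.2-fold higher number from compound 2 to compound 4 (0.09 log units; within the scatter). Compound 4 is therefore expected to give 2500 nM in this assay, with a range from 1000 nM to 6500 nM.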

Compound 4, concentration for 50% growth inhibition: 3020 nM
For compound 4 the middle estimate is 1.2-fold (0.08 log units) below the measured one; the range from low to high includes it.
By their numbers in this assay, from the lowest: compounds 1, 2, 3 and 4 (each within the scatter of the next).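

In this assay, amino in place of hydrogen on the aromatic carbon between two ring nitrogen atoms gives a 1.5-fold higher number from compound 2 to compound 4 (0.17 log units; within the scatter), so a group with a hydrogen-bond donor can stand at this place without a shift beyond the scatter. Amino in place of chloro on the same carbon gives a 2.0-fold higher number from compound 1 to compound 4 (0.30 log units; within the scatter), which is also printed as within the scatter, so hydrogen, chloro and amino at this carbon cannot be told apart in this assay. Among these compounds, no evidence on the compounds bears on this result.

On these data alone, it remains open whether this tolerance extends to larger groups on the same carbon, such as a dimethylamino group, a methoxy group or a longer alkylamine chain, any of which could show whether the place accepts more than a single heavy atom. Also open, as far as these compounds go, are whether amino at this carbon reads the same with the chloromethylbenzyl arrangement of compound 3, and what an amine or a thiol would do in place of the chloro group that remains on the shared core.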